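The source may report more compounds than this note shows. Statements on the series, on what has been measured and on what is new or still open speak of the compounds shown alone.

Measured so far in a functional assay on A549 cells (Homo sapiens), read by MTT assay, with a stated time of 72 h; on this read-out higher numbers stand for weaker inhibition and lower numbers for stronger inhibition:
- compound 1 `Nc1nc(N)c2c(-c3ccsc3)cn([C@@H]3O[C@H](CO)[C@@H](O)[C@H]3O)c2n1` gives > 100000 nM, a limit of the assay
- compound 2 `Cc1nc(N)c2c(-c3ccccc3)cn([C@@H]3O[C@H](CO)[C@@H](O)[C@H]3O)c2n1` gives > 20000 nM, a limit of the assay
- compound 3 `COc1nc(N)nc2c1c(-c1ccsc1)cn2[C@@H]1O[C@H](CO)[C@@H](O)[C@H]1O` gives > 100000 nM, a limit of the assay

Compound 2 therefore stands only at a limit in this assay; no number is known for it. The other two values in the series are limits as well, two of them sitting at the limit of > 100000 nM in this assay, at which 2 of the 3 values shown sit, and one at the limit of > 20000 nM in this assay, at which 1 of the 3 values shown sits.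

Compound 4 `Cc1nc(N)c2c(-c3ccco3)cn([C@@H]3O[C@H](CO)[C@@H](O)[C@H]3O)c2n1` differs from compound 2 by furan-2-yl in place of phenyl on an aromatic carbon. For the measured compounds named here, the one step known, a step that the two limits leave unreadable from compound 1 to compound 3, concerns another position and is left unreadable by the limits, so it does not bear on this exchange of the aromatic group. Compound 1, whose aromatic group is also a five-membered ring with one hetero atom, sits at a limit. Compound 3 with the same group does likewise. Going by the values given here, no measured step thus speaks for a change beyond the scatter, and in this assay the step that the limit leaves unreadable from compound 2 to compound 4 is expected to be none beyond the scatter, with a limit the likely outcome. Compound 4 is estimated at 50000 nM, in the range 10000 nM to 200000 nM.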

Compound 4, half-maximal inhibitory concentration: > 20000 nM
Compound 4 was reported as a limit; the forecaster's own chance of this, stated with the estimate: 80%; the middle value does not contradict the limit.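

Compound 2 and compound 4 both stand only at limits in this assay, so the exchange of phenyl for furan-2-yl gives no readable step. The compounds shown leave open whether the aromatic group affects inhibition at all, as none of the four has a number in this assay.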